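A Methyl in Place of Bromo: What Compound 4 Should Show

The source may hold more compounds than are shown below. What is called first, only, known or untested is meant among the compounds shown, and "the series" means these compounds.

In a functional assay on HL-60 cells (Homo sapiens) for cytotoxicity, read by luminescence and CellTiter-Glo, with a stated time of 3 days (a higher number here means a weaker inhibitor, a lower number a stronger inhibitor), three compounds have been measured:
Compound 1 `O=C(Nc1ccc(C(F)(F)F)cc1)c1cc(Br)ccc1O` gives 580 nM
Compound 2 `N#Cc1ccc(NC(=O)c2cc(-c3ccncc3)ccc2O)cc1` gives 5410 nM
Compound 3 `N#Cc1ccc(NC(=O)c2cc(Br)ccc2O)cc1` gives 620 nM

Among these three numbers compound 3 stands second highest. Its nearest neighbour is compound 1, and the step of a 1.1-fold higher number from compound 1 to compound 3 (0.03 log units; within the scatter) lies within the scatter, so the two cannot be ordered. The furthest is compound 2, and the step of an 8.7-fold lower number from compound 2 to compound 3 (0.94 log units; beyond the scatter) is beyond the scatter.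

Compound 4 `Cc1ccc(O)c(C(=O)Nc2ccc(C#N)cc2)c1` has not yet been measured. It differs from compound 3 in one place: methyl in place of bromo on an aromatic carbon

Going by the values given here, only one measured step touches this position, the step of an 8.7-fold lower number from compound 2 to compound 3 (0.94 log units; beyond the scatter), which shows that this carbon is one where the choice of group changes the number noticeably. Among the compounds with values here, no measured pair shows methyl against bromo, so the direction of the present change rests on no direct precedent. Within the data shown here, since the one step at this position was large, a change beyond the scatter is thought possible, and a moderate rise in the number, towards weaker inhibition, is expected for compound 4, with the step of a 2.4-fold higher number from compound 3 to compound 4 (0.38 log units; beyond the scatter) as the estimate. Compound 4 is therefore expected to give 1500 nM, in the range from 500 nM to 5000 nM.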

Compound 4, half-maximal inhibitory concentration: 3920 nM
Compound 4: middle estimate off by 2.6-fold (0.42 log units), on the low side, within the range that was stated.
By their numbers in this assay, from the lowest: compounds 1 and 3 (each within the scatter of the next); then compounds 4 and 2 (each within the scatter of the next).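

Going by these compounds alone, with this assay as the measure, compound 3 and compound 4 give the first direct comparison of methyl with bromo on this aromatic carbon, para to a hydroxy group, and the exchange raises the number clearly (a 6.3-fold higher number from compound 3 to compound 4 (0.80 log units; beyond the scatter)), even though each group counts one heavy atom, no ring, and no hydrogen-bond donors or acceptors. The earlier step at this carbon could have meant that pyridin-4-yl alone set itself apart, but methyl and pyridin-4-yl cannot be told apart here (a 1.4-fold lower number from compound 2 to compound 4 (0.14 log units; within the scatter)), so among the three groups seen at this position it is bromo that stands apart, with the lower number and with steps beyond the scatter to both others. Nothing given here bears on why bromo stands apart in this way.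

The compounds shown leave open how chloro, fluoro, a methoxy group or an amine on this carbon would compare with bromo and methyl. They also leave open whether methyl in place of bromo would give a similar step on the core of compound 1, which carries trifluoromethyl in place of cyano.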